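The source may hold more compounds than are shown below. What is called first, only, known or untested is meant among the compounds shown, and "the series" means these compounds.

Working notes on amide variants of one shared core, read in a functional assay on HepG2 cells (Homo sapiens), read by MTT assay, with a stated time of 48 h; on this read-out higher numbers stand for weaker inhibition and lower numbers for stronger inhibition. Among the compounds with values here, compound 2 `CCn1c(C(=O)NCCCN(C)C)ccc1C(CC)(CC)c1ccc(OCC(O)C(C)(C)C)c(C)c1` gives the only number so far, 360 nM. Compound 1 `CCOC(=O)CN(C)C(=O)c1ccc(C(CC)(CC)c2ccc(OCC(O)C(C)(C)C)c(C)c2)n1CC` reads > 50000 nM, which is a limit and not a number. Compound 3 `C#CCNC(=O)c1ccc(C(CC)(CC)c2ccc(OCC(O)C(C)(C)C)c(C)c2)n1CC` reads > 50000 nM, again a limit. Compound 3 therefore stands at the limit of > 50000 nM in this assay, at which 2 of the 3 values shown sit.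

The next change leads to compound 4 `CCn1c(C(=O)NCCN)ccc1C(CC)(CC)c1ccc(OCC(O)C(C)(C)C)c(C)c1`: aminomethyl in place of ethynyl on a saturated chain carbon bound to an amide-type nitrogen. Read one bond further out, this is propargylcarbamoyl to (2-aminoethyl)carbamoyl.

Within the data shown here, two measured steps bear on it: an at least 130-fold lower number from compound 1 to compound 2 (2.14 log units; beyond the scatter) and an at least 130-fold higher number from compound 2 to compound 3 (2.14 log units; beyond the scatter). Both are large, while a step that the two limits leave unreadable from compound 1 to compound 3 gives no readable size. Of the three measured compounds, only compound 2 has an amino group at the end of its chain, and compound 4 also has one. However, compound 4 carries the 2-aminoethyl chain, and no measured compound has it, so the full size of those steps is not assumed. A large move toward lower numbers is expected in this assay, and a result that stays at the limit remains possible. The expected change is an at least 16-fold lower number from compound 3 to compound 4 (1.22 log units; beyond the scatter). For compound 4 the estimated value is 3000 nM, with an expected range from 400 nM to 40000 nM.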

Compound 4, half-maximal inhibitory concentration: 176 nM
Beside the measured number, compound 4's estimate is 17-fold (1.23 log units) above it, and the stated range ends above it.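

In this assay, aminomethyl in place of ethynyl on a saturated chain carbon bound to an amide-type nitrogen gives an at least 280-fold lower number from compound 3 to compound 4 (2.45 log units; beyond the scatter), and (2-aminoethyl)amino in place of ((ethoxycarbonyl)methyl)(methyl)amino on a carbonyl carbon gives an at least 280-fold lower number from compound 1 to compound 4 (2.45 log units; beyond the scatter). Compound 2 no longer stands alone as the only amino-ended chain with a number, since amino in place of (dimethylamino)methyl gives a 2.0-fold lower number from compound 2 to compound 4 (0.31 log units; beyond the scatter), a modest step; among the four compounds shown, both amino-ended chains give numbers, and no compound goes against this. Compound 1 and compound 3 each remain a limit and not a number: the limit of > 50000 nM in this assay, at which 2 of the 4 values shown sit.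

The step from compound 2 to compound 4 changes the chain length and the methyl groups on the end nitrogen together, so the share of each in that step cannot be read. A 3-aminopropyl chain and a 2-(dimethylamino)ethyl chain would separate the two changes, and a carboxylic acid at the chain end would show whether a chain end other than an amine can also give a number in this assay.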